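Methyl in Place of Methoxy at the Assay Limit

The source may report more compounds than this note shows. Statements on the series, on what has been measured and on what is new or still open speak of the compounds shown alone.

Compound 1 `O=C1NC(=O)c2c1c1[nH]ncc1c1[nH]c3ccccc3c21`: > 100000 nM
Compound 2 `COc1ccc2[nH]c3c(c4c(c5ccnn53)C(=O)NC4=O)c2c1`: > 100000 nM

Of the compounds shown here, two have been measured in a functional assay on U-373MG ATCC cells (Homo sapiens) for cytotoxicity, read by MTT assay, with a stated time of 72 h; a lower number here means a stronger inhibitor, a higher number a weaker inhibitor. Compound 1 gives > 100000 nM, which is a limit of the assay and not a number. Compound 2 gives > 100000 nM, which is also a limit and not a number. Compound 2 therefore has no exact value, and neither compound can be ranked against the other. Both share one result: the limit of > 100000 nM in this assay, at which 2 of the 2 values shown sit.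

The next compound is compound 3 `Cc1ccc2[nH]c3c(c4c(c5ccnn53)C(=O)NC4=O)c2c1`. It carries methyl in place of methoxy on an aromatic carbon of a six-membered aromatic ring of carbon only, part of a fused or bridged system of five rings (methyl in place of methoxy on an aromatic carbon). Among the compounds with values here, no pair of measured compounds differs in one place alone, so no measured step can serve as a guide. In this assay no change beyond the usual scatter is expected, and the result may well be another limit. The estimated change is a number no higher from compound 2 to compound 3 (the limit leaves the size open). The expected value for compound 3 is 100000 nM, with an estimated range from 30000 nM to 300000 nM.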

Compound 3, half-maximal inhibitory concentration: 57000 nM
Estimate against measurement, compound 3: 1.8-fold (0.24 log units) above; measured number inside the range.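

In this assay, within the data shown here, compound 3 gives 57000 nM, the only value shown that is a number and not a limit, so with methyl at this position on the six-membered aromatic ring the assay returns a reading. Methyl in place of methoxy on an aromatic carbon gives an at least 1.7-fold lower number from compound 2 to compound 3 (0.24 log units; that floor lies within the scatter), which can be read only as a floor, and that floor does not by itself establish a change beyond the usual scatter. The set as a whole still rests mostly on a single reading, with only compound 3 giving a number: the limit of > 100000 nM in this assay, at which 2 of the 3 values shown sit.

Going by these compounds, what remains open is how far compound 2 truly lies from compound 3, and whether the difference between methoxy and methyl matters at all in this assay. On these data alone, it also remains open what an amine, a chlorine atom or a longer chain such as ethyl would do at the same aromatic carbon, and whether any such group would bring the reading further from the limit than methyl does.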